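Sulfoxide chromones: varying the aryl ether substituent

A few compounds are considered here, and "the series" means these few. Any claim that something is new, unique, unknown or untested is made for them only; others in the source may bear on it.

Measured compounds in a functional assay on DLD-1 cells (Homo sapiens) for cytotoxicity, with a stated time of 48 h; a lower number here means a stronger inhibitor, a higher number a weaker inhibitor:
compound 1 `CCC(=O)Oc1ccc2oc(/C=C/[S+](C)[O-])cc(=O)c2c1` gives 9000 nM
compound 2 `CCCCCOc1ccc2oc(/C=C/[S+](C)[O-])cc(=O)c2c1` gives 6600 nM
compound 3 `COc1ccc2oc(/C=C/[S+](C)[O-])cc(=O)c2c1` gives 5700 nM

Compound 3 has the lowest number of the three, but its gaps to compound 1 and compound 2 are both within the scatter, so no order among them can be read. The next compound is compound 4 `CCCCC(=O)Oc1ccc2oc(/C=C/[S+](C)[O-])cc(=O)c2c1`, with the change (butylcarbonyl in place of methyl on an oxygen on an aromatic ring). Within the data shown here, the closest precedent is the reverse of the step of a 1.6-fold lower number from compound 1 to compound 3 (0.20 log units; within the scatter), which was within the scatter, as were a 1.4-fold lower number from compound 1 to compound 2 (0.13 log units; within the scatter) and a 1.2-fold lower number from compound 2 to compound 3 (0.06 log units; within the scatter). Replacing methyl by propanoyl or pentyl thus moved the number little, and the same is expected of butylcarbonyl: compound 4 is expected at 7500 nM, between 4000 nM and 15000 nM, a step of a 1.3-fold higher number from compound 3 to compound 4 (0.12 log units; within the scatter) that stays within the scatter.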

Compound 4, half-maximal inhibitory concentration: 6700 nM
Compound 4: middle estimate off by 1.1-fold (0.05 log units), on the high side; the measured number falls inside the stated range.
By their numbers in this assay, from the lowest: compounds 3, 2, 4 and 1 (each within the scatter of the next).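

In this assay, lengthening the acyl chain on this oxygen gives a 1.3-fold lower number from compound 1 to compound 4 (0.13 log units; within the scatter), so acyl length does not separate these two compounds. Exchanging pentyl for butylcarbonyl, which adds a carbonyl at this oxygen, gives a 1.0-fold higher number from compound 2 to compound 4 (0.01 log units; within the scatter), and replacing methyl gives a 1.2-fold higher number from compound 3 to compound 4 (0.07 log units; within the scatter), so all four substituents remain indistinguishable here. No supporting data bear on the reason for this flat response.

Still open, on these data alone, is whether a free hydroxyl, an amine-bearing chain or a carboxylic acid on this oxygen would move the number beyond the scatter. Changes elsewhere on the shared core also remain open.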